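The source may report more compounds than this note shows. Statements on the series, on what has been measured and on what is new or still open speak of the compounds shown alone.

Measured so far:
compound 1 `Cc1cccc(/C=N/Nc2ncc3c(n2)n(C2CCCC2)c(=O)c(=O)n3C)c1` — in a functional assay on A549 cells (Homo sapiens) for antiproliferative activity, read by MTT assay (on this read-out lower numbers stand for stronger inhibition and higher numbers for weaker inhibition), compound 1 gives 34500 nM
compound 2 `COc1cccc(/C=N/Nc2ncc3c(n2)n(C2CCCC2)c(=O)c(=O)n3C)c1` — in this assay compound 2 gives 27400 nM
compound 3 `Cn1c(=O)c(=O)n(C2CCCC2)c2nc(N/N=C/c3ccc(C(F)(F)F)cc3)ncc21` — in this assay compound 3 gives 40600 nM

Compound 1 stands second highest of these three numbers; its nearest neighbour is compound 3, a 1.2-fold higher number from compound 1 to compound 3 (0.07 log units; within the scatter), and its furthest is compound 2, a 1.3-fold lower number from compound 1 to compound 2 (0.10 log units; within the scatter), so all three sit close together and none can be called stronger or weaker than another.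

Compound 4 `Cc1cc(C)c(/C=N/Nc2ncc3c(n2)n(C2CCCC2)c(=O)c(=O)n3C)c(C)c1` has not yet been measured. It differs from compound 1 in one place: 2,4,6-trimethylphenyl in place of 3-methylphenyl on a carbon with a double bond to nitrogen. For the measured compounds named here, no measured step makes this same exchange, so the expectation rests on the steps that change the ring attached to the carbon with a double bond to nitrogen: a 1.3-fold lower number from compound 1 to compound 2 (0.10 log units; within the scatter), a 1.2-fold higher number from compound 1 to compound 3 (0.07 log units; within the scatter) and a 1.5-fold higher number from compound 2 to compound 3 (0.17 log units; within the scatter), each within the scatter. Since swapping methyl, methoxy and trifluoromethyl on that ring left this assay essentially unchanged, for compound 4 no step beyond the scatter is expected in either direction. The estimated step is a 1.0-fold higher number from compound 1 to compound 4 (0.01 log units; within the scatter). For compound 4 the expected number is 35000 nM, with a range from 15000 nM to 80000 nM.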

Compound 4, half-maximal inhibitory concentration: 12000 nM
The estimate for compound 4 lay 2.9-fold (0.46 log units) above the measured number; the measured number lies below the stated range.
By their numbers in this assay, from the lowest: compound 4; then compounds 2, 1 and 3 (each within the scatter of the next).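

At this position, on a carbon with a double bond to nitrogen, the earlier exchanges of the ring had left this assay within the scatter, so the ring could have seemed not to matter. 2,4,6-trimethylphenyl breaks that picture, with a 2.9-fold lower number from compound 1 to compound 4 (0.46 log units; beyond the scatter) and a 2.3-fold lower number from compound 2 to compound 4 (0.36 log units; beyond the scatter) and a 3.4-fold lower number from compound 3 to compound 4 (0.53 log units; beyond the scatter), all beyond the scatter but modest, so the ring's identity can shift this read-out after all. Nothing available explains why this ring behaves differently from the other three.

A single compound cannot show whether the lower number needs all the methyl groups of 2,4,6-trimethylphenyl together or only some of them. From the compounds shown here alone, it also remains open how a phenyl ring carrying an amine or a carboxylic acid, or a pyridine ring, would behave here.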